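A few compounds are considered here, and "the series" means these few. Any claim that something is new, unique, unknown or untested is made for them only; others in the source may bear on it.

For the measured compounds named here, compound 2 `COc1cc(/C=C/C(=O)/C=C(\NCc2ccccc2)SC)cc(OC)c1OC` carries the highest of the two numbers so far in an ADME assay on Vero cells (Chlorocebus sabaeus) for cytotoxicity, read by MTT assay, with a stated time of 72 h (a higher number here means that more compound is tolerated, a lower number that less compound is tolerated), where compound 2 gives 71500 nM. Its nearest neighbour is compound 1 `COc1cc(/C=C/C(=O)/C=C(\Nc2ccccc2)SC)cc(OC)c1OC`, which in this assay gives 64600 nM; the step from compound 1 to compound 2 was a 1.1-fold higher number from compound 1 to compound 2 (0.04 log units; within the scatter), so the two compounds are not separated by this assay. Compound 3 `COc1cc(/C=C/C(=O)/C=C(\Nc2ccc(Cl)cc2)SC)cc(OC)c1OC` is not yet measured. It differs from compound 2 by 4-chlorophenyl in place of benzyl on an amine nitrogen. Going by the values given here, the only step that bears on this change is the one from compound 1 to compound 2, which exchanged phenyl for benzyl on the same nitrogen and was a 1.1-fold higher number from compound 1 to compound 2 (0.04 log units; within the scatter). Among the compounds with values here, compound 3 returns to an aryl group on that nitrogen, now with chlorine on the ring, and no measured step speaks to the chlorine itself. The expected step from compound 2 to compound 3 in this assay is therefore small, a 1.3-fold lower number from compound 2 to compound 3 (0.11 log units; within the scatter), and compound 3 is estimated at 55000 nM, with a range from 25000 nM to 120000 nM.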

Compound 3, half-maximal cytotoxic concentration: 57900 nM
Estimate against measurement, compound 3: 1.1-fold (0.02 log units) below; measured number inside the range.
By their numbers in this assay, from the lowest: compounds 3, 1 and 2 (each within the scatter of the next).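

Chloro in place of hydrogen on an aromatic carbon, a change the earlier compounds could not speak to, gave a 1.1-fold lower number from compound 1 to compound 3 (0.05 log units; within the scatter) in this assay. The exchange of benzyl for 4-chlorophenyl on the amine nitrogen gave a 1.2-fold lower number from compound 2 to compound 3 (0.09 log units; within the scatter), so phenyl, benzyl and 4-chlorophenyl at this position are not separated by this assay. Nothing at hand gives a reason for these numbers.

Going by these compounds, it remains open whether a different kind of group on this nitrogen, such as a longer alkyl chain, or a different group on the phenyl ring, such as a carboxylic acid or an amine, would move the number beyond the scatter. On these data alone, it is equally open whether any change to the shared core, rather than to this nitrogen, would do so.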